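This account rests on a few compounds, and the source may have more. Where it says the series, first, only, none or still open, it means among the compounds named here.

The series shares the core of compound 2 `C/C(=N\NC(=O)/C(C#N)=C/c1ccc(Br)cc1)c1c(O)c2ccc(O)cc2oc1=O` and varies the aryl group on a double-bonded chain carbon bound to a double-bonded chain carbon. In a functional assay on NRK-49F cells (Rattus norvegicus) for cytotoxicity, read by MTT assay, with a stated time of 24 h (on this read-out higher numbers stand for weaker inhibition and lower numbers for stronger inhibition), compound 2 gives 49600 nM. Compound 1 `COc1cc(/C=C(\C#N)C(=O)N/N=C(\C)c2c(O)c3ccc(O)cc3oc2=O)cc(OC)c1OC` gives 55300 nM in this assay, and compound 3 `C/C(=N\NC(=O)/C(C#N)=C/c1ccccc1[N+](=O)[O-])c1c(O)c2ccc(O)cc2oc1=O` gives 68600 nM. Compound 2 thus carries the smallest of the three numbers, but its gaps to compound 1 and to compound 3 are within the scatter, so no order among the three can be claimed. Among the compounds with values here, the only single-point step measured is a 1.4-fold higher number from compound 2 to compound 3 (0.14 log units; within the scatter); exchanging the aryl group has so far not moved the read-out beyond the scatter.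

Compound 4 `C/C(=N\NC(=O)/C(C#N)=C/c1cccc(Br)c1)c1c(O)c2ccc(O)cc2oc1=O` is the next step from compound 2: 3-bromophenyl in place of 4-bromophenyl on a double-bonded chain carbon bound to a double-bonded chain carbon. The step from compound 2 to compound 3 is the one that bears on it, and that step was within the scatter. Within the data shown here, no measured step compares 3-bromophenyl with 4-bromophenyl directly, so the expectation rests on the insensitivity seen so far. Compound 4 is therefore expected to stay close to compound 2, with a 1.0-fold higher number from compound 2 to compound 4 (0.00 log units; within the scatter) expected to lie within the scatter. The estimate for compound 4 in this assay is 50000 nM, with a range from 25000 nM to 100000 nM.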

Compound 4, half-maximal inhibitory concentration: 59400 nM
Estimate against measurement, compound 4: 1.2-fold (0.07 log units) below; the range from low to high includes it.
By their numbers in this assay, from the lowest: compounds 2, 1, 4 and 3 (each within the scatter of the next).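

In this assay, within the data shown here, 3-bromophenyl in place of 4-bromophenyl on a double-bonded chain carbon bound to a double-bonded chain carbon gives a 1.2-fold higher number from compound 2 to compound 4 (0.08 log units; within the scatter) and is the first measured step in which the entering and leaving groups hold the same atoms, joined differently; this rearrangement stays within the scatter. 3-Bromophenyl in place of 2-nitrophenyl at the same place gives a 1.2-fold lower number from compound 3 to compound 4 (0.06 log units; within the scatter) and also stays within the scatter, so 4-bromophenyl, 3-bromophenyl and 2-nitrophenyl cannot be told apart on this read-out, and the insensitivity seen earlier now extends to a change in how the bromophenyl group is joined. No measurement at hand offers an explanation for this flat response.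

From the compounds shown here alone, whether an amine or a carboxylic acid on the phenyl ring, or a longer chain in place of the aryl group, would move the number beyond the scatter remains open. Equally open, going by these compounds, is whether a read-out other than this assay would separate 3-bromophenyl from 4-bromophenyl at all.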